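Removing a hydroxyl-bearing side chain from a kinase inhibitor

The source may report more compounds than this note shows. Statements on the series, on what has been measured and on what is new or still open speak of the compounds shown alone.

Measured so far:
compound 1, `Cc1c(Nc2nc(N)c3c(C#N)c(N4CCC[C@H]4C)n(C)c3n2)cnn1CC(C)(C)O`: 120 nM
compound 2, `Cc1nn(C)cc1Nc1nc(N)c2c(C#N)c(N3CCC[C@H]3C)n(C)c2n1`: 120 nM

Both compounds share one core and were tested in an assay on HEK293 cells for inhibition of Leucine-rich repeat serine/threonine-protein kinase 2 variant G2019S (Homo sapiens), with a stated time of 48 h; a lower number here means a stronger inhibitor, a higher number a weaker inhibitor. Compound 1 gives 120 nM, and compound 2 gives 120 nM; the two values are level at the digits shown, so neither can be called stronger than the other.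

Compound 3, `Cc1c(Nc2nc(N)c3c(C#N)c(N4CCC[C@H]4C)n(C)c3n2)cnn1C`, has not been measured. It differs from compound 1 in one place: hydrogen in place of 1-hydroxy-1-methylethyl on a saturated chain carbon bound to an aromatic nitrogen. Compound 1 sits level with compound 2, which also carries no 1-hydroxy-1-methylethyl group and gives 120 nM, which suggests that this part of the molecule is not what sets the potency here. The step from compound 1 to compound 3 is therefore expected to be small, with no clear direction beyond the scatter: a 1.1-fold higher number from compound 1 to compound 3 (0.03 log units; within the scatter). Compound 3 is estimated at 130 nM, in a range from 50 nM to 350 nM.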

Compound 3, half-maximal inhibitory concentration: 260 nM
Compound 3: the middle estimate sits 2.0-fold (0.30 log units) below what was measured; low and high end bracket the measured number.
By their numbers in this assay, from the lowest: compounds 1 and 2 (each within the scatter of the next); then compound 3.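

In this assay cutting 2-hydroxy-2-methylpropyl back to methyl gives a 2.2-fold higher number from compound 1 to compound 3 (0.34 log units; beyond the scatter) and so shows that the side chain at this position does count for something, though only modestly. Exchanging 1,3-dimethyl-1H-pyrazol-4-yl for 1,5-dimethyl-1H-pyrazol-4-yl on the shared core gives a 2.2-fold higher number from compound 2 to compound 3 (0.34 log units; beyond the scatter) as well, so where the methyl groups sit also matters. The level values of compounds 1 and 2 had hidden both effects, which only came into view with compound 3 as the shared point of comparison.

Nothing measured here says why these steps occur. From the compounds shown here alone, it also stays open whether the hydroxyl or the chain length carries the difference, which a plain isobutyl chain, or an amine in place of the hydroxyl, could help to separate.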